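The compounds below may be only part of what the source reports. "The series", "measured", "known", "first", "only" and "open" are said of these compounds alone.

Of the compounds shown here, two built on the same core have been measured in an assay on isolated protein for inhibition of 2-Hydroxyacid oxidase 2 (Rattus norvegicus); a lower number here means a stronger inhibitor, a higher number a weaker inhibitor. Compound 1, `Cc1n[nH]c(C(=O)O)c1Cc1cccc(C(F)(F)F)c1`, carries a trifluoromethyl on its pendant ring; in this assay compound 1 gives 300 nM. Compound 2, `Cc1n[nH]c(C(=O)O)c1Cc1ccc(-c2ccc(F)cc2)cc1`, carries a fluorophenyl on that ring instead; in this assay compound 2 gives 400 nM. These two numbers lie within the usual scatter of each other, so neither compound can be called the stronger inhibitor on this evidence.

The next compound, compound 3, `Cc1n[nH]c(C(=O)O)c1Cc1cccc(C#N)c1`, has not yet been measured. It differs from compound 1 in one place: cyano in place of trifluoromethyl on an aromatic carbon. Going by the values given here, no pair of measured compounds shows what this particular exchange does, so any expectation must rest on compound 1 alone and on the modest size of the swap. A small weakening or no change beyond the scatter seems most likely, and a step of about a 1.7-fold higher number from compound 1 to compound 3 (0.22 log units; within the scatter) is expected. Compound 3 is therefore estimated to give 500 nM in this assay, with a plausible range from 150 nM to 1500 nM, pending the actual measurement.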

Compound 3, half-maximal inhibitory concentration: 500 nM
Compound 3: the middle estimate sits on the measured number at the digits printed, and the stated range covers the measured number.
By their numbers in this assay, from the lowest: compounds 1, 2 and 3 (each within the scatter of the next).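

Replacing trifluoromethyl with cyano on this aromatic carbon gives a 1.7-fold higher number from compound 1 to compound 3 (0.22 log units; within the scatter) in this assay, so this first measured one-place exchange in the set does not separate the two compounds. The two groups differ in their heavy atoms and in their hydrogen-bond acceptors, since cyano counts one acceptor and trifluoromethyl none, yet the step stays within the usual scatter of repeated measurements, which means this position has so far shown no measurable preference between them. No separate measurement is available to explain why the two groups read alike.

From the compounds shown here alone, two groups are a narrow test of a position, so it remains open whether an amine, a methoxy group or a second carboxylic acid on this same carbon would produce a step beyond the scatter, and what a plain hydrogen there would give as a baseline. Going by these compounds, it also remains open whether the same exchange of trifluoromethyl for cyano would stay as quiet on a different carbon of the pendant ring or on a version of the core with an amide in place of its carboxylic acid.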